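Halogenated aryl sulfone expected to restore binding

The source may report more compounds than this note shows. Statements on the series, on what has been measured and on what is new or still open speak of the compounds shown alone.

Compound 3 `COc1ccc(S(=O)(=O)c2cnc3cc(Cl)ccc3c2N2CCC(C)CC2)cc1` stands lowest of the three measured compounds in an assay on isolated protein for displacement of a labelled ligand from metabotropic glutamate receptor 5 (Homo sapiens), with a stated time of 60 min, tested at 1 uM (a lower number here means less inhibition, a higher number more inhibition at the concentration tested (going by the name of the read-out)), where compound 3 gives 79%. In this assay compound 1 `CC1CCN(c2c(S(=O)(=O)c3cc(F)cc(F)c3)cnc3cc(Cl)ccc23)CC1` gives 94%, and compound 2 `CC1CCN(c2c(S(=O)(=O)c3cccc(Cl)c3)cnc3cc(Cl)ccc23)CC1` gives 92%. Compound 4 `CC1CCN(c2c(S(=O)(=O)c3ccc(F)c(Cl)c3)cnc3cc(Cl)ccc23)CC1` differs from compound 3 in one place: 3-chloro-4-fluorophenyl in place of 4-methoxyphenyl on a sulfonyl sulfur. Within the data shown here, two measured steps bear on this change: the step of a number 15 percentage points lower from compound 1 to compound 3 (beyond the scatter) and the step of a number 13 percentage points lower from compound 2 to compound 3 (beyond the scatter). Both show that a 4-methoxyphenyl on the sulfonyl sulfur gives a lower number than a 3,5-difluorophenyl or a 3-chlorophenyl there. Moving back to a halogen-bearing phenyl, compound 4 is expected to show a gain beyond the scatter, about a number 13 percentage points higher from compound 3 to compound 4 (beyond the scatter). Compound 4 is therefore estimated at 92%, with a range from 84% to 97%.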

Compound 4, a percentage reported as inhibition, at one concentration (the size of the read-out at that concentration, not a potency): 94%
Estimate against measurement, compound 4: 2 percentage points below; the measured number falls inside the stated range.
By their numbers in this assay, from the lowest: compound 3; then compounds 2, 1 and 4 (each within the scatter of the next).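

In this assay, the 3-chloro-4-fluorophenyl group gives a number 15 percentage points higher from compound 3 to compound 4 (beyond the scatter), so a third halogen-bearing phenyl on the sulfonyl sulfur now stands apart from 4-methoxyphenyl. Fluoro in place of hydrogen gives a number 2 percentage points higher from compound 2 to compound 4 (within the scatter), and the exchange for 3,5-difluorophenyl gives no change at the digits printed from compound 1 to compound 4 (within the scatter), so these three halogen patterns cannot be told apart here. Nothing measured on these compounds accounts for the gap to compound 3. Going by these compounds, it remains open whether an amine or a carboxylic acid on this phenyl ring would give a number like compound 3 or like compound 4.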